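The source may report more compounds than this note shows. Statements on the series, on what has been measured and on what is new or still open speak of the compounds shown alone.

Measured so far:
compound 1 `O=C(COc1ccc(F)cc1)Nc1nc(-c2ccc(Br)cc2)cs1` — 45300 nM
compound 2 `O=C(COc1ccc(F)cc1)Nc1nc(-c2ccc(Cl)cc2)cs1` — 35900 nM

Of the compounds shown here, two have been measured in a functional assay on Ehrlich cells (Mus musculus) for cytotoxicity, read by trypan blue exclusion, with a stated time of 48 h; on this read-out higher numbers stand for weaker inhibition and lower numbers for stronger inhibition. For the measured compounds named here, compound 1 gives 45300 nM, and its only measured neighbour, compound 2, differs from it by a 1.3-fold lower number from compound 1 to compound 2 (0.10 log units; within the scatter), a step that stays within the scatter, so the two numbers cannot be told apart.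

Compound 3 `Cc1ccc(OCC(=O)Nc2nc(-c3ccc(Br)cc3)cs2)cc1` has not yet been measured. It differs from compound 1 by methyl in place of fluoro on an aromatic carbon. Going by the values given here, the only measured step, from compound 1 to compound 2, changes a halogen on the other aromatic ring of the shared core, not the fluoro that compound 3 replaces by methyl, so no measured step bears directly on this change. Among the compounds with values here, the one step that exists was within the scatter, and nothing measured here points to a larger move in this assay in either direction. The estimate for compound 3 is therefore a step of a 1.0-fold lower number from compound 1 to compound 3 (0.00 log units; within the scatter) from compound 1, that is no change beyond the scatter. Compound 3 is expected to give 45000 nM in this assay, within a range from 20000 nM to 100000 nM.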

Compound 3, half-maximal inhibitory concentration: 55300 nM
The estimate for compound 3 lay 1.2-fold (0.09 log units) below the measured number, within the range that was stated.
By their numbers in this assay, from the lowest: compounds 2, 1 and 3 (each within the scatter of the next).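

For the compounds shown here, until now, the only measured change in this assay was a halogen on the other aromatic ring, so compound 3 is the first to probe the ring that carries the fluoro, where that atom sits para to a large group. Going from 4-fluorophenoxy to 4-methylphenoxy gives a 1.2-fold higher number from compound 1 to compound 3 (0.09 log units; within the scatter) and so leaves the two numbers impossible to tell apart: at this place, exchanging one fluorine atom for one carbon atom produces no readable change. No measured information is available to explain this result.

Fluoro and methyl each add only one heavy atom, so it remains open whether a bigger or differently built group at this place, such as an amine, a carboxylic acid or a longer alkyl chain, would shift the number beyond the scatter. It is also open whether methyl in place of fluoro would behave the same way on the chloro compound 2, since this change is shown here only with the bromo group in place.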